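The source may report more compounds than this note shows. Statements on the series, on what has been measured and on what is new or still open speak of the compounds shown alone.

Of the compounds shown here, three sharing one core have been tested in a functional assay on MGC-803 cells (Homo sapiens) for inhibition, read by MTT assay, with a stated time of 72 h; on this read-out higher numbers stand for weaker inhibition and lower numbers for stronger inhibition. Compound 1, `Cc1cc(Nc2cc(-c3ccccc3)[nH]n2)n2nc(SCc3ccc([N+](=O)[O-])cc3)nc2n1`, gives 4250 nM in this assay, the highest number of the three. Compound 2, `Cc1cc(Nc2cc(-c3ccccc3)[nH]n2)n2nc(SCc3nc4ccccc4[nH]3)nc2n1`, gives 1790 nM. Compound 3, `Cc1cc(Nc2ccn(Cc3nc(C)c4ccccc4n3)n2)n2nc(SCc3ccc(Br)cc3)nc2n1`, differs from compound 1 in several places at once. Compound 3 gives 960 nM. Within the data shown here, the only single-point change recorded is a 2.4-fold lower number from compound 1 to compound 2 (0.38 log units; beyond the scatter), 1H-benzimidazol-2-yl in place of 4-nitrophenyl on a saturated chain carbon bound to a sulfur.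

Compound 4, `Cc1cc(Nc2cc(-c3ccccc3)[nH]n2)n2nc(SCc3ccc(C(F)(F)F)cc3)nc2n1`, differs from compound 1 in one place: trifluoromethyl in place of nitro on an aromatic carbon. Among the measured compounds shown here, no measured step exchanges one group for another on that same six-membered aromatic ring, so the step from compound 1 to compound 2 bears on it only loosely, showing that replacing the group carried by the chain can shift the number a modest way. Lacking a direct precedent, the change is expected to stay within the scatter or to lower the number only slightly. Compound 4 is therefore estimated at 3500 nM (range 1500 nM to 8000 nM), which is expected to amount to a 1.2-fold lower number from compound 1 to compound 4 (0.08 log units; within the scatter).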

Compound 4, half-maximal inhibitory concentration: 3520 nM
Beside the measured number, compound 4's estimate is 1.0-fold (0.00 log units) below it; low and high end bracket the measured number.
By their numbers in this assay, from the lowest: compounds 3, 2, 4 and 1 (each within the scatter of the next, the first and the last beyond it).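

Trifluoromethyl in place of nitro is the only step so far that changes a group on the six-membered aromatic ring itself, and in this assay it gives a 1.2-fold lower number from compound 1 to compound 4 (0.08 log units; within the scatter), so at this place the two groups cannot be told apart. The second step, a 2.0-fold higher number from compound 2 to compound 4 (0.29 log units; within the scatter), shows that 4-(trifluoromethyl)phenyl and 1H-benzimidazol-2-yl on the chain carbon also cannot be told apart here, although the step from 4-nitrophenyl to 1H-benzimidazol-2-yl lay beyond the scatter. Nothing measured here explains either result.

As far as these compounds go, a single exchange says little about the ring in general, and it remains open whether an amine or a carboxylic acid at this place would shift the number further. Also open, from the compounds shown here alone, is whether the same exchange would read alike on a compound built like compound 3.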